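Thiazolyl amide replacing thiazolinone amide: efficacy outlook

The compounds below may be only part of what the source reports. "The series", "measured", "known", "first", "only" and "open" are said of these compounds alone.

compound 1 `CNC(=O)[C@H](c1ccc(Cl)cc1)C(C)C`: 66%
compound 2 `CC(C)[C@H](C(=O)NC1=NC(=O)CS1)c1ccc(Cl)cc1`: 96%

In a functional assay on CHO cells for agonist activity at Free fatty acid receptor 2 (Homo sapiens), read by cAMP accumulation (a higher number here means a larger maximal response, a lower number a smaller maximal response), compound 2 stands highest of the two numbers; its nearest neighbour is compound 1, with a number 30 percentage points higher from compound 1 to compound 2 (beyond the scatter). Compound 3 `CC(C)[C@H](C(=O)Nc1ncc(C#N)s1)c1ccc(Cl)cc1` differs from compound 2 in one place: a group of 7 heavy atoms (4 carbon, 2 nitrogen, 1 sulfur; one five-membered aromatic ring with 2 hetero atoms) in place of a group of 6 heavy atoms (3 carbon, 1 nitrogen, 1 oxygen, 1 sulfur; one five-membered non-aromatic ring with 2 hetero atoms), on an amide-type nitrogen. Within the data shown here, only the step from compound 1 to compound 2 touches the same amide-type nitrogen, and it concerns a group in place of one carbon atom, not one ring in place of another, so it gives limited guidance. Compound 3 is therefore expected to stay near compound 2, with a step of a number 8 percentage points lower from compound 2 to compound 3 (within the scatter) that may not exceed the scatter. The estimate for compound 3 is 88%, within 68% to 105%.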

Compound 3, largest response reached (reported as efficacy), in percent of the reference or control that the assay uses: 105%
Compound 3: the middle estimate sits 17 percentage points below what was measured, within the range that was stated.
By their numbers in this assay, from the lowest: compound 1; then compounds 2 and 3 (each within the scatter of the next).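

In this assay, 5-cyano-1,3-thiazol-2-yl replaces the non-aromatic five-membered ring on the amide-type nitrogen with a number 9 percentage points higher from compound 2 to compound 3 (within the scatter), so an aromatic ring and a non-aromatic ring cannot be told apart at this position. Against methyl, the same group gives a number 39 percentage points higher from compound 1 to compound 3 (beyond the scatter), so the higher response seen with compound 2 over compound 1 also holds for a second, aromatic ring. Nothing available explains why the two rings give such similar responses. 

Among these compounds, whether the nitrile is needed remains open, since no compound here carries an amine or a carboxylic acid in its place. Also open, as far as these compounds go, is whether a phenyl ring on the amide-type nitrogen would keep this response.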